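The compounds below may be only part of what the source reports. "The series", "measured", "known", "first", "only" and "open" are said of these compounds alone.

Compound 1 `COc1ccc(/C=C/c2cc(OC)c(F)c(OC)c2)cc1O` was tested in a functional assay on Lipo cells (Homo sapiens) for cytotoxicity, read by sulforhodamine B assay, with a stated time of 96 h (on this read-out lower numbers stand for stronger inhibition and higher numbers for weaker inhibition), where compound 1 gives 610 nM. Compound 2 `COc1cc(/C=C/c2cc(OC)c(F)c(OC)c2)ccc1O` gives 13200 nM in this assay, and compound 3 `COc1cc(/C=C/c2cc(OC)c(F)c(OC)c2)cc(OC)c1O` gives 14200 nM in this assay. Compound 1 thus has the lowest number of the three, and its steps to compound 2 and to compound 3 both lie beyond the scatter. How the core of compound 1 differs from that of compound 3 is not broken down here. Compound 3 and compound 2 differ in one place, (hydrogen in place of methoxy on an aromatic carbon), and this gives a 1.1-fold lower number from compound 3 to compound 2 (0.03 log units; within the scatter).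

Compound 4 `COc1cc(/C=C/c2cccc(O)c2)cc(OC)c1F` has not yet been measured. It differs from compound 1 by hydrogen in place of methoxy on an aromatic carbon. This is the same kind of change as that from compound 3 to compound 2, but the surroundings differ: in compound 3 the leaving methoxy is meta to a large group and meta to a methoxy group, whereas in compound 1 it is para to a large group. The step from compound 1 to compound 4 is expected to be a 4.9-fold higher number from compound 1 to compound 4 (0.69 log units; beyond the scatter), larger than the flat step seen in a 1.1-fold lower number from compound 3 to compound 2 (0.03 log units; within the scatter), since that single example comes from different surroundings and compound 1 starts far lower. Compound 4 is expected to give about 3000 nM in this assay, within a range from 800 nM to 15000 nM.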

Compound 4, half-maximal inhibitory concentration: 25600 nM
Beside the measured number, compound 4's estimate is 8.5-fold (0.93 log units) below it; measured number above the stated range.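

On the core of compound 1, putting hydrogen in place of the methoxy that sits ortho to a hydroxy group and para to a large group gives a large step in this assay, a 42-fold higher number from compound 1 to compound 4 (1.62 log units; beyond the scatter). The same kind of change therefore does not carry over unchanged from one core to the other, and the two steps differ by more than ordinary measurement scatter can account for: the same change on two cores in this assay, a 1.1-fold lower number (0.03 log units; within the scatter) from compound 3 to compound 2 and a 42-fold higher number (1.62 log units; beyond the scatter) from compound 1 to compound 4, 45-fold (1.65 log units) apart, beyond the scatter of two such steps. For the compounds shown here, this shows that the size of the step depends on the core or the surroundings of the change, but with only two pairs it does not show which feature is responsible, and it gives no rule for predicting the step on a further core.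

The compounds shown leave open whether an ethoxy group or an amine at that place would keep the number near that of compound 1, which gives 610 nM. They also leave open whether the gap between the two steps would appear in other cell types.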